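Aminothiophene series: ester to benzoyl at the carbonyl carbon

The source may hold more compounds than are shown below. What is called first, only, known or untested is meant among the compounds shown, and "the series" means these compounds.

Measured so far:
- compound 1 `Nc1sc(Br)c(-c2cccc(C(F)(F)F)c2)c1C(=O)c1ccccc1`: 47.5%
- compound 2 `CCOC(=O)c1c(-c2cccc(C(F)(F)F)c2)csc1N`: 93%

Working notes. In an assay on CHO-K1 cells for displacement of a labelled ligand from adenosine receptor A1 (Homo sapiens), tested at 10 uM (on this read-out lower numbers stand for less inhibition and higher numbers for more inhibition at the one concentration tested (going by the name of the read-out)), compound 2 gives 93%, the highest of the two numbers recorded; its nearest neighbour on this read-out is compound 1, which gives 47.5%, a gap beyond the usual scatter. For the measured compounds named here, no pair that differs in one place has been measured, so nothing about this gap can be tied to a single change.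

Compound 3 `Nc1scc(-c2cccc(C(F)(F)F)c2)c1C(=O)c1ccccc1` has not yet been measured in this assay. Against compound 2 the difference is phenyl in place of ethoxy on a carbonyl carbon. Compound 3 thus carries the benzoyl group that compound 1 also carries, and compound 1 gives 47.5%, well under the value of compound 2. On this basis a drop from compound 2 to compound 3 is expected, of a size beyond the scatter, estimated as a number 35 percentage points lower from compound 2 to compound 3 (beyond the scatter). Compound 3 is expected to give about 58% in this assay, with a plausible range from 30% to 88%; how it compares with compound 1 will only be clear once the number is in hand.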

Compound 3, a percentage reported as inhibition, at one concentration (the size of the read-out at that concentration, not a potency): 61.1%
For compound 3 the middle estimate is 3.1 percentage points below the measured one, within the range that was stated.
By their numbers in this assay, from the lowest: compound 1; then compound 3; then compound 2.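

Phenyl in place of ethoxy on a carbonyl carbon now stands as a single change in this assay, and it gives a number 31.9 percentage points lower from compound 2 to compound 3 (beyond the scatter), so ethoxycarbonyl to benzoyl can be read on its own at this position, with the benzoyl compound still showing inhibition at the one concentration tested. The same measurement also gives a second single change, hydrogen in place of bromo on an aromatic carbon, with a number 13.6 percentage points higher from compound 1 to compound 3 (beyond the scatter), so the earlier gap between the two first compounds can now be split into two separately measured steps, of which the change at the carbonyl carbon is the larger. No measurement is available that explains either step.

On these data alone, what remains open is how other groups on the carbonyl carbon would read, such as methoxy, a longer chain such as butoxy, or an amine giving an amide, and whether anything there would match the ethoxy value. As far as these compounds go, it also remains open whether bromo on the aromatic carbon would give a step of similar size and direction with ethoxycarbonyl in place of benzoyl, and how these single-concentration numbers relate to potency.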